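Aryl swap at the amide of compound 3

This account rests on a few compounds, and the source may have more. Where it says the series, first, only, none or still open, it means among the compounds named here.

Measured so far in a functional assay on HeLa cells (Homo sapiens) for antiproliferative activity, with a stated time of 24 h; on this read-out lower numbers stand for stronger inhibition and higher numbers for weaker inhibition:
compound 1 `NC(=O)c1c(NC(=O)c2ccc(C(F)(F)F)cc2)sc2c1CCN(Cc1ccc(Cl)cc1)C2` — > 50000 nM
compound 2 `NC(=O)c1c(NC(=O)c2ccc(C(F)(F)F)cc2)sc2c1CCN(Cc1ccc(Cl)cc1Cl)C2` — > 50000 nM
compound 3 `NC(=O)c1c(NC(=O)c2ccccc2Br)sc2c1CCN(C(=S)Nc1ccccc1Cl)C2` — 46900 nM

In this assay, among the measured compounds shown here, compound 3 holds the only number, 46900 nM, and stands weak. Compound 1 reports only the limit > 50000 nM. Compound 2 likewise reports only the limit > 50000 nM. For the measured compounds named here, the sole measured step, a step that the two limits leave unreadable from compound 1 to compound 2, is unreadable because of the limit of > 50000 nM in this assay, at which 2 of the 3 values shown sit.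

Compound 4 `NC(=O)c1c(NC(=O)c2ccc(C(F)(F)F)cc2)sc2c1CCN(C(=S)Nc1ccccc1Cl)C2` differs from compound 3 by 4-(trifluoromethyl)phenyl in place of 2-bromophenyl on a carbonyl carbon. Going by the values given here, no measured step covers this change. The two compounds carrying the 4-(trifluoromethyl)phenyl amide, compound 1 and compound 2, both sit at the limit, so the step of a 1.3-fold higher number from compound 3 to compound 4 (0.11 log units; within the scatter) is expected to be small or toward weaker inhibition. Compound 4 is estimated at 60000 nM, range 20000 nM to 200000 nM.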

Compound 4, half-maximal inhibitory concentration: 44000 nM
For compound 4 the middle estimate is 1.4-fold (0.13 log units) above the measured one; measured number inside the range.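

In this assay the swap on the carbonyl carbon stays within the scatter (a 1.1-fold lower number from compound 3 to compound 4 (0.03 log units; within the scatter)), so this aryl change alone does not lift the compounds out of the weak range. Changing the group on the amine nitrogen in a ring yields only floors (an at least 1.1-fold lower number from compound 2 to compound 4 (0.05 log units; that floor lies within the scatter)) and (an at least 1.1-fold lower number from compound 1 to compound 4 (0.05 log units; that floor lies within the scatter)). On these data alone, these steps stay open-ended because compound 1 and compound 2 each report a limit: the limit of > 50000 nM in this assay, at which 2 of the 4 values shown sit.

As far as these compounds go, whether an amine or a carboxylic acid on the amide's phenyl ring would shift the number remains open. So does the effect of a longer chain on the amine nitrogen in a ring.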